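Oleyl ketone heterocycle series: acetal replacing the ketone warhead

The source may report more compounds than this note shows. Statements on the series, on what has been measured and on what is new or still open speak of the compounds shown alone.

Measured compounds:
- compound 1 `CCCCCCCC/C=C\CCCCCCC(=O)c1nnn(C)n1`: 65 nM
- compound 2 `CCCCCCCC/C=C\CCCCCCC(=O)c1nc2ncccc2o1`: 2.3 nM
- compound 3 `CCCCCCCC/C=C\CCCCCCC(=O)c1nc2ccccc2o1`: 370 nM

All three share the same unsaturated chain and a carbonyl bearing a heteroaryl group, and differ only in that heteroaryl. In an assay on isolated protein for inhibition of Fatty-acid amide hydrolase 1 (Homo sapiens) (a lower number here means a stronger inhibitor, a higher number a weaker inhibitor), compound 1 sits second highest of the three numbers: a 28-fold lower number from compound 1 to compound 2 (1.45 log units; beyond the scatter), while a 5.7-fold higher number from compound 1 to compound 3 (0.76 log units; beyond the scatter), and the two neighbours lie apart by a 160-fold higher number from compound 2 to compound 3 (2.21 log units; beyond the scatter).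

Compound 4 `CCCCCCCC/C=C\CCCCCCCC(OC)OC` moves away from this pattern in a different way: 2,2-dimethoxyethyl in place of (2-methyl-2H-tetrazol-5-yl)carbonyl on a saturated chain carbon, six bonds along the chain from a double-bonded chain carbon. Going by the values given here, none of the measured steps bears on this change. Each of them swaps one heteroaryl for another on a carbonyl that is kept; none removes the carbonyl itself, and none tests an open, non-aromatic terminus on the chain. The measured steps therefore give scale only: a single change at the chain end has already produced a 160-fold higher number from compound 2 to compound 3 (2.21 log units; beyond the scatter) in this assay within the series, so a change that removes both the carbonyl and the aromatic ring is expected to be at least of that order, and in the weaker direction.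

Compound 4 is therefore expected to show a 460-fold higher number from compound 1 to compound 4 (2.66 log units; beyond the scatter), giving an estimate of 30000 nM for compound 4 with a plausible range of 4000 nM to 200000 nM, with a real chance that this assay reports only a limit.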

Compound 4, inhibition constant: > 300000 nM
Compound 4 was reported as a limit (the forecaster's own chance of this, stated with the estimate: 40%); middle value at least 10-fold (1.00 log units) from the limit.
By their numbers in this assay, from the lowest: compound 2; then compound 1; then compound 3. At a limit, above all of these: compound 4.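

Compound 4 is reported in this assay only as a limit, not as a number: the limit of > 300000 nM in this assay, at which 1 of the 4 values shown sits.

Putting 2,2-dimethoxyethyl in place of (2-methyl-2H-tetrazol-5-yl)carbonyl at this chain end gives an at least 4600-fold higher number from compound 1 to compound 4 (3.66 log units; beyond the scatter), and this exceeds the widest gap among the heteroaryl ketones, a 160-fold higher number from compound 2 to compound 3 (2.21 log units; beyond the scatter). Going by these compounds alone, the earlier compounds all kept the carbonyl and an aromatic ring and showed only how far the number moves when the heteroaryl is swapped, whereas this open, ringless acetal terminus is the first change to take the number out of the measurable range of this assay. The same unsaturated chain is therefore not enough on its own to give a measurable number when it ends in this acetal.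

The carbonyl and the aromatic ring leave together in this one step, so the result does not apportion the loss between them. A methyl ketone on the same chain would test the carbonyl without a ring, a 2-benzoxazolyl group joined through a methylene rather than a carbonyl would test the ring without the carbonyl, and a carboxylic acid terminus remains an open comparison.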